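Acetoxy on the benzyloxy ring of compound 3

The source may report more compounds than this note shows. Statements on the series, on what has been measured and on what is new or still open speak of the compounds shown alone.

Working notes. In a functional assay on HL-60 cells (Homo sapiens) for antiproliferative activity, tested at 1 uM (on this read-out lower numbers stand for a weaker effect and higher numbers for a stronger effect at the one concentration tested), compound 3 `COc1ccc(C(=O)NOCc2ccccc2)cc1S(=O)(=O)Nc1ccc2c(c1)cc(C)c(=O)n2C` gives 2%; compound 2 `CC(=O)Oc1ccc(CONC(=O)c2ccc(CS(=O)(=O)Nc3ccc4cc(C)c(=O)n(C)c4c3)cc2)cc1` gives 3% and compound 1 `Cc1cc2cc(NS(=O)(=O)Cc3ccc(C(=O)NO)cc3)ccc2n(C)c1=O` gives 5%, so the three numbers sit together with no gap beyond the usual scatter of this assay, and compound 3 is not separated from either of the others.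

Compound 4 `COc1ccc(C(=O)NOCc2ccc(OC(C)=O)cc2)cc1S(=O)(=O)Nc1ccc2c(c1)cc(C)c(=O)n2C` differs from compound 3 in one place: acetoxy in place of hydrogen on an aromatic carbon. Among the measured compounds shown here, no measured pair in this set carries this same change, so no step can be counted for it; the nearest hint is compound 2, which carries an acetoxy group on its benzyl and also gives a small number. The step from compound 3 to compound 4 is therefore expected to be a number 1 percentage points higher from compound 3 to compound 4 (within the scatter), that is, none beyond the scatter. For compound 4 the expected value is 3%, in the range -5% to 12%.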

Compound 4, a percentage reported as inhibition, at one concentration (the size of the read-out at that concentration, not a potency): 0%
For compound 4 the middle estimate is 3 percentage points above the measured one; low and high end bracket the measured number.
By their numbers in this assay, from the lowest: compounds 4, 3, 2 and 1 (each within the scatter of the next).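

In this assay, the change from benzyloxy to (4-acetoxybenzyl)oxy gives a number 2 percentage points lower from compound 3 to compound 4 (within the scatter). Among the compounds shown here, this is the first single-place comparison, and at this position the acetoxy group does not separate the pair at the one concentration tested. No evidence bears on this result.

From the compounds shown here alone, it remains open whether an amine or a carboxylic acid at the same ring carbon would move the read-out beyond the scatter. Going by these compounds, whether compound 3 and compound 4 would stay together at other concentrations also remains open.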